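The source may hold more compounds than are shown below. What is called first, only, known or untested is meant among the compounds shown, and "the series" means these compounds.

Measured compounds: compound 1 `ClCc1ccccc1Cn1cnc2c(Cl)nc(Cl)nc21` with 3380 nM; compound 2 `ClCc1cccc(Cn2cnc3c(Cl)nc(Cl)nc32)c1` with 17000 nM; compound 3 `Nc1nc(Cl)c2ncn(Cc3ccccc3CCl)c2n1` with 23400 nM.

All three values come from a functional assay on SF-295 cells (Homo sapiens) for cytotoxicity, read by sulforhodamine B assay, with a stated time of 48 h; a lower number here means a stronger inhibitor of growth, a higher number a weaker inhibitor of growth. Compound 1 and compound 2 are built from the same atoms joined differently; the difference between the two cores is not broken down here, and their two values are simply what they show. Compound 3 arises from compound 1 by amino in place of chloro on an aromatic carbon, a step that gave a 6.9-fold higher number from compound 1 to compound 3 (0.84 log units; beyond the scatter). Compound 4 `Nc1nc(Cl)c2ncn(Cc3cccc(CCl)c3)c2n1` has not yet been measured; it arises from compound 2 by amino in place of chloro on an aromatic carbon, the same change at the same place as before. Since compound 1 to compound 3 showed a 6.9-fold higher number from compound 1 to compound 3 (0.84 log units; beyond the scatter), a step of similar size is expected from compound 2, giving an expected 4.7-fold higher number from compound 2 to compound 4 (0.67 log units; beyond the scatter). The value expected for compound 4 in this assay is 80000 nM, likely between 25000 nM and 150000 nM.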

Compound 4, concentration for total growth inhibition: 14500 nM
Beside the measured number, compound 4's estimate is 5.5-fold (0.74 log units) above it, outside the stated range (below it).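

In this assay, amino in place of chloro on an aromatic carbon gave a 1.2-fold lower number from compound 2 to compound 4 (0.07 log units; within the scatter), so the change did not carry over from one core to the other with the same size: the same change on two cores in this assay, a 6.9-fold higher number (0.84 log units; beyond the scatter) from compound 1 to compound 3 and a 1.2-fold lower number (0.07 log units; within the scatter) from compound 2 to compound 4, 8.1-fold (0.91 log units) apart, beyond the scatter of two such steps. In this series, then, the size of this step depends on the core that carries it, at least across these two pairs. Two pairs alone do not show which feature of the cores sets the steps apart, nor how the change would behave on a further core.

The compounds shown leave open whether a methoxy group or a dimethylamine at that carbon would follow the step of either core. They also leave open whether the gap between the two steps would hold in other cell lines.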